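Notes on compound 4: dipropylamino for cyclopentylamino

The source may hold more compounds than are shown below. What is called first, only, known or untested is meant among the compounds shown, and "the series" means these compounds.

Compound 1 `O=C1C(NC2CCCC2)=CC(=O)c2c1nc1n2[C@H]2OC[C@@H](O)[C@H]2OC1` was tested in a functional assay on HeLa cells (Homo sapiens) for inhibition, read by sulforhodamine B assay; on this read-out lower numbers stand for stronger inhibition and higher numbers for weaker inhibition. In this assay compound 1 gives > 16000 nM, which is a limit of the assay and not a number. Compound 2 `O=C1C=C(NC2CCCC2)C(=O)c2c1nc1n2[C@H]2OC[C@@H](O)[C@H]2OC1` is a regioisomer of compound 1 bearing the same cyclopentylamino group. In this assay compound 2 gives > 16000 nM, again a limit. Compound 3 `O=C1C=C(Nc2cccc(Cl)c2)C(=O)c2c1nc1n2[C@H]2OC[C@@H](O)[C@H]2OC1` gives 6040 nM in this assay. Going by the values given here, the only measured step is an at least 2.6-fold lower number from compound 2 to compound 3 (0.42 log units; beyond the scatter); it concerns a different replacement on the regioisomeric scaffold and does not bear directly on the present change.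

Compound 4 `CCCN(CCC)C1=CC(=O)c2c(nc3n2[C@H]2OC[C@@H](O)[C@H]2OC3)C1=O` differs from compound 1 by dipropylamino in place of cyclopentylamino on a double-bonded ring carbon. Among the compounds with values here, no measured step covers an alkyl-for-alkyl exchange at this position; both compounds carrying a saturated amine substituent sit at the limit (the limit of > 16000 nM in this assay, at which 2 of the 3 values shown sit). No step beyond the scatter is expected. Compound 4 is estimated at 20000 nM, between 8000 nM and 50000 nM. The step that the limit leaves unreadable from compound 1 to compound 4 is expected to remain within scatter, and most likely only a limit will again be reported.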

Compound 4, half-maximal inhibitory concentration: > 16000 nM
Compound 4 ended at the assay's limit (the forecaster's own chance of this, stated with the estimate: 70%); the middle value lies beyond the limit too.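

No step can be read from compound 1 to compound 4, since both results are limits and not numbers: the limit of > 16000 nM in this assay, at which 3 of the 4 values shown sit.

The compounds shown leave open whether dipropylamino and cyclopentylamino differ at all on this core, and how far either compound lies from the limit.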